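A few compounds are considered here, and "the series" means these few. Any claim that something is new, unique, unknown or untested is made for them only; others in the source may bear on it.

Measured compounds:
compound 1, `C=CCN1C(=O)C(=O)c2cc(-c3ccc(OC)cc3)ccc21`: 390 nM
compound 2, `COc1ccc(-c2ccc3c(c2)C(=O)C(=O)N3Cc2ccc(C(F)(F)F)cc2)cc1`: 270 nM

Both were tested in a functional assay on K562 cells (Homo sapiens) for antiproliferative activity, read by MTT assay, with a stated time of 48 h; a lower number here means a stronger inhibitor, a higher number a weaker inhibitor. In this assay compound 1 gives 390 nM, and compound 2 gives 270 nM. Compound 1 stands apart from compound 2 only by a 1.4-fold lower number from compound 1 to compound 2 (0.16 log units; within the scatter), a step within the scatter, so on the numbers shown the two compounds cannot be told apart.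

Compound 3, `COc1ccc(-c2ccc3c(c2)C(=O)C(=O)N3Cc2ccc3ccccc3c2)cc1`, has not yet been measured. It differs from compound 1 in one place: naphthalen-2-yl in place of vinyl on a saturated chain carbon bound to an amide-type nitrogen in a ring. Within the data shown here, the only measured step that bears on this is the one from compound 1 to compound 2, where the vinyl was also replaced by an aromatic group on the same saturated chain carbon; that step, a 1.4-fold lower number from compound 1 to compound 2 (0.16 log units; within the scatter), stayed within the scatter. On that basis a step of similar size is expected here, and no change beyond the scatter is anticipated. The step from compound 1 to compound 3 is estimated as a 1.5-fold lower number from compound 1 to compound 3 (0.18 log units; within the scatter). For compound 3 the expected value in this assay is 260 nM, with a range from 90 nM to 750 nM.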

Compound 3, half-maximal inhibitory concentration: 400 nM
Estimate against measurement, compound 3: 1.5-fold (0.19 log units) below; measured number inside the range.
By their numbers in this assay, from the lowest: compounds 2, 1 and 3 (each within the scatter of the next).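

In this assay, the group on the saturated chain carbon bound to an amide-type nitrogen in a ring now runs from vinyl through 4-(trifluoromethyl)phenyl to naphthalen-2-yl, and both steps that bring in naphthalen-2-yl, a 1.0-fold higher number from compound 1 to compound 3 (0.01 log units; within the scatter) and a 1.5-fold higher number from compound 2 to compound 3 (0.17 log units; within the scatter), leave the compounds impossible to tell apart. The earlier pair showed this only for a single aromatic ring, whereas compound 3 shows that 10 heavy atoms in 2 six-membered aromatic rings can take the place of the 2 heavy atoms of vinyl with no change beyond the scatter, so at this position, among these three compounds, the size of the group makes no readable difference. No other measurement accompanies these compounds that could explain this flat result.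

Vinyl and naphthalen-2-yl are both hydrocarbon groups with no net charge, so it remains open whether an amine or a carboxylic acid on this chain carbon would stay in the same range. Going by these compounds, it also remains open whether the same flat result would hold with a different shared core or in other cell lines.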